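From hydroxymethyl to hydroxy on a shared core

A few compounds are considered here, and "the series" means these few. Any claim that something is new, unique, unknown or untested is made for them only; others in the source may bear on it.

- Compound 1 `NC(=O)c1cn([C@H]2C[C@H](O)[C@@H](CO)O2)c(=O)[nH]c1=O`: > 200000 nM
- Compound 2 `O=c1[nH]c(=O)n([C@H]2C[C@H](O)[C@@H](CO)O2)cc1CO`: 120000 nM

In an ADME assay on CEM-SS cells (Homo sapiens) for cytotoxicity, read by MTT assay (a higher number here means that more compound is tolerated, a lower number that less compound is tolerated), compound 1 gives > 200000 nM, which is a limit of the assay and not a number. Among the compounds with values here, compound 2 gives 120000 nM, the only actual number so far, and its standing can be read only against (the limit of > 200000 nM in this assay, at which 1 of the 2 values shown sits).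

Compound 3 `O=c1[nH]c(=O)n([C@H]2C[C@H](O)[C@@H](CO)O2)cc1O` has not yet been measured. It carries hydroxy in place of hydroxymethyl on an aromatic carbon.

Within the data shown here, the one measured step also exchanges a group on an aromatic carbon: an at least 1.6-fold lower number from compound 1 to compound 2 (0.22 log units; that floor lies within the scatter). Resting on that single step, no change beyond the scatter is expected in this assay, and a reading at the limit would not be a surprise.

The step expected is a 1.2-fold lower number from compound 2 to compound 3 (0.08 log units; within the scatter).

For compound 3 the estimated value is 100000 nM, within an expected range of 35000 nM to 200000 nM.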

Compound 3, half-maximal cytotoxic concentration: > 200000 nM
Compound 3 gave a limit, no number (the forecaster's own chance of this, stated with the estimate: 35%); at least 2.0-fold (0.30 log units) between middle value and limit.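

In this assay compound 3 ends at a limit of the assay, not at a number, so hydroxy at this position on the aromatic carbon joins carbamoyl there. Hydroxy in place of hydroxymethyl gives an at least 1.6-fold higher number from compound 2 to compound 3 (0.22 log units; that floor lies within the scatter), and this floor alone does not establish a change beyond the scatter, though the true step could be larger. Of the three groups at this position, only hydroxymethyl has given an actual number, while carbamoyl and hydroxy both leave the reading at the limit: the limit of > 200000 nM in this assay, at which 2 of the 3 values shown sit.

The step between compound 1 and compound 3 cannot be read, as both values are limits. As far as these compounds go, whether an amine or a carboxylic acid on this aromatic carbon would give a number in this assay or would also reach the limit remains open.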